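A propylcarbamoyl group added to compound 1

The compounds below may be only part of what the source reports. "The series", "measured", "known", "first", "only" and "open" are said of these compounds alone.

Compound 1 `CC[C@@H]1C(=O)N(C)c2cnc(-n3ccc4ccccc43)nc2N1C1CCCC1`: 57500 nM
Compound 2 `CCCNC(=O)c1ccc2c(ccn2-c2ncc3c(n2)N(c2ccn(C)n2)C(CC)C(=O)N3C)c1`: "not active" (no number reported)

Among the compounds with values here, in a functional assay on A549 cells (Homo sapiens) for antiproliferative activity, read by CCK-8 assay, with a stated time of 72 h (on this read-out higher numbers stand for weaker inhibition of growth and lower numbers for stronger inhibition of growth), compound 1 gives the only number so far, 57500 nM, while compound 2 is reported as "not active" (no number reported), without a number. The next compound to be tested is compound 3 `CCCNC(=O)c1ccc2c(ccn2-c2ncc3c(n2)N(C2CCCC2)[C@H](CC)C(=O)N3C)c1`, which differs from compound 1 in one place: propylcarbamoyl in place of hydrogen on an aromatic carbon. The propylcarbamoyl stands in place of hydrogen on an aromatic carbon of a six-membered aromatic ring of carbon only. Within the data shown here, no measured step exists to guide the size of this change. Compound 2 also carries propylcarbamoyl and is reported as "not active" (no number reported), which argues against expecting a large gain. A modest strengthening of growth inhibition is expected, though a result within the scatter or without a number remains possible. The estimated change is a 3.8-fold lower number from compound 1 to compound 3 (0.58 log units; beyond the scatter). For compound 3 the estimated value is 15000 nM, with an expected range of 2500 nM to 80000 nM.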

Compound 3, concentration for 50% growth inhibition: 1640 nM
Estimate against measurement, compound 3: 9.1-fold (0.96 log units) above, outside the stated range (below it).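

In this assay, the carbon of the six-membered aromatic ring of carbon only, meta to a fused ring and para to a fused ring, proves to be a place where a substituent can strengthen growth inhibition: propylcarbamoyl in place of hydrogen gives a 35-fold lower number from compound 1 to compound 3 (1.54 log units; beyond the scatter), a large step and the first measured one in this set. Compound 1 alone gave a single weak number and could not show that growth inhibition responds to a change at this carbon. Nothing available here explains the size of this step.

Whether the gain depends on the propyl chain, the amide hydrogen or the carbonyl remains open, as propylcarbamoyl is the only group shown at this carbon on the core of compound 1. A methylcarbamoyl group, a longer chain, a carboxylic acid or an amine at the same carbon would help to separate these possibilities.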